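Amide variation on a shared core: cyclopropyl for propyl

The source may hold more compounds than are shown below. What is called first, only, known or untested is meant among the compounds shown, and "the series" means these compounds.

Compound 1 `CCCC(=O)Nc1cc(Oc2ccc(Nc3nccc4[nH]cc(-c5ccc(F)cc5)c(=O)c34)cc2F)ccn1` — 23.5%
Compound 2 `CCC(=O)Nc1cc(Oc2ccc(Nc3nccc4[nH]cc(-c5ccc(F)cc5)c(=O)c34)cc2F)ccn1` — 68.7%
Compound 3 `O=C(CO)Nc1cc(Oc2ccc(Nc3nccc4[nH]cc(-c5ccc(F)cc5)c(=O)c34)cc2F)ccn1` — 18.5%

The three measured compounds share one core and differ only in the acyl group on the amide nitrogen. In a functional assay on HT-29 cells (Homo sapiens) for antiproliferative activity, read by MTT assay, with a stated time of 72 h, tested at 10 uM (a higher number here means more inhibition at the concentration tested (going by the name of the read-out), a lower number less inhibition), compound 1 stands second highest of the three: compound 3 lies close, a number 5 percentage points lower from compound 1 to compound 3 (within the scatter), while compound 2 lies far above, a number 45.2 percentage points higher from compound 1 to compound 2 (beyond the scatter). Compound 4 `O=C(Nc1cc(Oc2ccc(Nc3nccc4[nH]cc(-c5ccc(F)cc5)c(=O)c34)cc2F)ccn1)C1CC1` is not yet measured; its change from compound 1 is cyclopropyl in place of propyl on a carbonyl carbon. The step that bears on it is the large rise seen when the acyl chain is shortened from compound 1 to compound 2, whereas the hydroxy-bearing group falls far back, a number 50.2 percentage points lower from compound 2 to compound 3 (beyond the scatter). Among the measured compounds shown here, no measured step introduces a ring, so the expected size is uncertain, but a compact acyl group is expected to move upward. Compound 4 is estimated at 45% (range 15% to 75%), an expected step of a number 21.5 percentage points higher from compound 1 to compound 4 (beyond the scatter).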

Compound 4, a percentage reported as inhibition, at one concentration (the size of the read-out at that concentration, not a potency): 25.5%
For compound 4 the middle estimate is 19.5 percentage points above the measured one, and the stated range covers the measured number.
By their numbers in this assay, from the lowest: compounds 3, 1 and 4 (each within the scatter of the next); then compound 2.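

In this assay, cyclopropyl on the carbonyl carbon does not reach the level of ethyl (a number 43.2 percentage points lower from compound 2 to compound 4 (beyond the scatter)), so a short acyl group alone does not carry the high value of compound 2. Cyclopropyl is not separated from propyl (a number 2 percentage points higher from compound 1 to compound 4 (within the scatter)) or from hydroxymethyl (a number 7 percentage points higher from compound 3 to compound 4 (within the scatter)), leaving compound 2 alone above the other three at this position. No measured evidence accounts for the gap between ethyl and cyclopropyl.

Going by these compounds, whether the level of compound 2 depends on an unbranched ethyl chain remains open. Methyl or isopropyl on the carbonyl carbon would bear on this.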